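The source may report more compounds than this note shows. Statements on the series, on what has been measured and on what is new or still open speak of the compounds shown alone.

Compound 2 `Cc1cccc(S(=O)(=O)Nc2ccc(N3CCN(c4cccc(-c5c(C(=O)NCCCN6CCN(C)CC6)c(C)n(C)c5-c5ccc(Cl)cc5)c4)CC3)cc2)c1` is the reference for this step. In an assay for inhibition of Apoptosis regulator Bcl-2 (Homo sapiens), read by fluorescence polarization, with a stated time of 2 h (a lower number here means a stronger inhibitor, a higher number a weaker inhibitor), compound 2 gives 689 nM, the second highest of the three numbers in hand. Among the measured compounds shown here, compound 1 `Cc1c(C(=O)NCCCN2CCN(C)CC2)c(-c2cccc(N3CCN(c4ccc(NS(=O)(=O)c5cccc(OC(C)C)c5)cc4)CC3)c2)c(-c2ccc(Cl)cc2)n1C` gives 2020 nM in this assay, and the only one-place step among the measured compounds, a 2.9-fold lower number from compound 1 to compound 2 (0.47 log units; beyond the scatter), alters the substituent on the ring of the benzenesulfonamide. For the measured compounds named here, compound 3 `CCn1c(C)c(C(=O)O)c(-c2cccc(N3CCN(c4ccc(NS(=O)(=O)c5ccc(N[C@H](CCN6CCC(O)CC6)CSc6ccccc6)c(S(=O)(=O)C(F)(F)F)c5)cc4)CC3)c2)c1-c1ccc(Cl)cc1` differs from compound 2 in several places at once and also carries a (trifluoromethyl)sulfonyl group; no single step to it can be drawn. In this assay compound 3 gives 5.4 nM.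

Compound 4 `Cc1c(C(=O)NCCCN2CCN(C)CC2)c(-c2cccc(N3CCN(c4ccc(NS(=O)(=O)c5cccc(S(=O)(=O)C(F)(F)F)c5)cc4)CC3)c2)c(-c2ccc(Cl)cc2)n1C` is the next compound: (trifluoromethyl)sulfonyl in place of methyl on an aromatic carbon. The step from compound 1 to compound 2 is the only measured one on the same ring, and it was modest, so a step of similar or somewhat larger size toward a lower number is expected. The value of compound 3 in this assay, 5.4 nM, is consistent with that direction but cannot be separated from its other changes. Compound 4 is therefore expected to give 400 nM in this assay, within 120 nM to 1400 nM, an estimated step of a 1.7-fold lower number from compound 2 to compound 4 (0.24 log units; within the scatter).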

Compound 4, half-maximal inhibitory concentration: 153 nM
Estimate against measurement, compound 4: 2.6-fold (0.42 log units) above; low and high end bracket the measured number.
By their numbers in this assay, from the lowest: compound 3; then compound 4; then compound 2; then compound 1.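

The a 4.5-fold lower number from compound 2 to compound 4 (0.65 log units; beyond the scatter) shows that this place on the aromatic ring, meta to a large group, accepts (trifluoromethyl)sulfonyl, and the number falls further than it did with methyl. With a 13-fold lower number from compound 1 to compound 4 (1.12 log units; beyond the scatter), the three compounds that differ only here run in this assay from isopropoxy through methyl to (trifluoromethyl)sulfonyl, and the earlier step alone could not show that a group with more heavy atoms than methyl would give the lowest number of the three. No measurement shown here accounts for this order.

As far as these compounds go, how an amine or a carboxylic acid at this place would read in this assay remains open. The other changes carried by compound 3, at 5.4 nM, also remain unseparated from this one.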